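A few compounds are considered here, and "the series" means these few. Any claim that something is new, unique, unknown or untested is made for them only; others in the source may bear on it.

Measured so far:
compound 1, `CCCC(=O)c1c(O)c(Cl)c(O)c(Cl)c1O`: 21500 nM
compound 2, `CCCCCC(=O)c1c(O)c(Br)c(OC)c(Br)c1O`: 3700 nM
compound 3, `CCCCC(=O)c1c(OC)c(Cl)c(OC)c(Cl)c1OC`: 23500 nM

In a functional assay on the whole organism (S2 cells, strain S2) for inhibition, with Drosophila as the target, read by a luciferase reporter, with stated times of 1.5 h and 8 h (a higher number here means a weaker inhibitor, a lower number a stronger inhibitor), compound 1 gives 21500 nM, the second highest of the three numbers. Compound 3 gives 23500 nM, which lies within the scatter of compound 1, so the two cannot be told apart. Compound 2 gives 3700 nM, a lower number beyond the scatter; it differs from compound 1 in several places at once, so no single change can be credited.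

Compound 4, `CCCCCCCC(=O)c1c(O)c(Cl)c(O)c(Cl)c1O`, is not yet measured. It differs from compound 1 in one way: butyl in place of hydrogen on a saturated chain carbon, three bonds along the chain from a carbonyl carbon. For the measured compounds named here, no measured pair shows this exact change alone. Going by the values given here, the only hint comes from compound 2, which carries a longer chain and gives 3700 nM, yet its other differences cloud the reading. A moderate step toward a lower number is expected, of size a 3.1-fold lower number from compound 1 to compound 4 (0.49 log units; beyond the scatter), with a real chance that it stays within the scatter. Compound 4 is therefore estimated at 7000 nM, within 2000 nM to 25000 nM.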

Compound 4, half-maximal inhibitory concentration: 3700 nM
Compound 4: the middle estimate sits 1.9-fold (0.28 log units) above what was measured; low and high end bracket the measured number.
By their numbers in this assay, from the lowest: compounds 2 and 4 (each within the scatter of the next); then compounds 1 and 3 (each within the scatter of the next).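

In this assay, butyl in place of hydrogen on a saturated chain carbon, three bonds along the chain from a carbonyl carbon, brings a 5.8-fold lower number from compound 1 to compound 4 (0.76 log units; beyond the scatter) with nothing else altered. This is the first change among the compounds shown that sits in one place alone, so the lower number can now be credited to the longer chain rather than to a mix of differences. Nothing measured here accounts for the step.

From the compounds shown here alone, whether a still longer chain would lower the number further or reverse the step stays open, as does whether a branched chain, a phenyl group or a carboxylic acid at the chain end would serve at this place. It is also unknown whether the same lengthening would bring a similar step on the cores of compound 2 or compound 3.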